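Nitro on the pyrazole-phenyl: expected effect in compound 4

This account rests on a few compounds, and the source may have more. Where it says the series, first, only, none or still open, it means among the compounds named here.

Three compounds of the series have been run. Compound 1 `CSc1nn(-c2ccccc2)c2nc(Nc3ccccc3)n(-c3ccccc3)c(=O)c12` gives 25.4% in a functional assay on the whole organism (strain Wistar albino) for inhibition, with Rattus norvegicus as the target, read by paw edema, with a stated time of 3 h, at a dose of 25 mg/kg by the oral route; on this read-out higher numbers stand for more inhibition at the one dose given (going by the name of the read-out) and lower numbers for less inhibition. Compound 2 `CSc1nn(-c2ccc([N+](=O)[O-])cc2)c2nc(Nc3ccccc3)n(-c3ccccc3)c(=O)c12` gives 26.6% in this assay; the change from compound 1 to compound 2 is nitro in place of hydrogen on an aromatic carbon, and the step is a number 1.2 percentage points higher from compound 1 to compound 2 (within the scatter). Compound 3 `O=c1c2c(Nc3ccc(Cl)cc3)nn(-c3ccccc3)c2nc(Nc2ccccc2)n1-c1ccccc1` gives 28.7% in this assay; it differs from compound 1 in the core by (4-chlorophenyl)amino in place of methylsulfanyl on an aromatic carbon, and the step is a number 3.3 percentage points higher from compound 1 to compound 3 (within the scatter). The values of compound 2 and compound 3 lie within the scatter of each other, so no order among the three is claimed.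

Compound 4 `O=c1c2c(Nc3ccc(Cl)cc3)nn(-c3ccc([N+](=O)[O-])cc3)c2nc(Nc2ccccc2)n1-c1ccccc1` has not been run. It differs from compound 3 by nitro in place of hydrogen on an aromatic carbon. This is the same change already made from compound 1 to compound 2, at a place described in the same words, and it occurs twice among the compounds shown. The two cores differ as described above for compound 1 and compound 3.

Going by the values given here, on the one precedent, the step for this change was a number 1.2 percentage points higher from compound 1 to compound 2 (within the scatter), within the scatter. The expectation is that the same change on the core of compound 3 behaves alike, giving an expected step of a number 1.3 percentage points higher from compound 3 to compound 4 (within the scatter) in this assay, which rests on the step from compound 1 to compound 2 and on compound 3 giving 28.7%. Compound 4 is therefore estimated at 30% in this assay, with a range from 22% to 38%; this estimate rests on a single precedent and carries the scatter of the read-out.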

Compound 4, a percentage reported as inhibition, in the whole organism at one dose (the size of the read-out at that dose, not a potency): 20.6%
Estimate against measurement, compound 4: 9.4 percentage points above; the measured number lies below the stated range.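

In this assay, nitro in place of hydrogen on the phenyl of the core of compound 3 gives a number 8.1 percentage points lower from compound 3 to compound 4 (within the scatter), and set beside the same change on the core of compound 1, the two steps do not separate: the same change on two cores in this assay, a number 1.2 percentage points higher (within the scatter) from compound 1 to compound 2 and a number 8.1 percentage points lower (within the scatter) from compound 3 to compound 4, 9.3 percentage points apart, within the scatter of two such steps Read the other way round, (4-chlorophenyl)amino in place of methylsulfanyl with the nitro group present gives a number 6 percentage points lower from compound 2 to compound 4 (within the scatter), and this too does not separate from the earlier step: the same change on two cores in this assay, a number 3.3 percentage points higher (within the scatter) from compound 1 to compound 3 and a number 6 percentage points lower (within the scatter) from compound 2 to compound 4, 9.3 percentage points apart, within the scatter of two such steps The four compounds therefore give no ground for saying that the nitro change behaves differently on the two cores, but they do not show that it carries over unchanged either, since each step lies within the scatter, so neither a direction nor a size can be assigned to the change on either core.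

Open, as far as these compounds go, is whether any replacement on this phenyl, para to a large group, moves the read-out beyond the scatter, for instance an amine or a carboxylic acid in place of nitro. Equally open, from the compounds shown here alone, is whether a longer chain on the sulfur in place of methylsulfanyl would separate the cores, and whether these steps hold at any dose or time other than the single one read here.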